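The compounds below may be only part of what the source reports. "The series", "measured", "known", "first", "only" and "open" are said of these compounds alone.

Within the data shown here, in an ADME assay on microsomes from liver (Mus musculus) for metabolic stability, read by mass spectrometry, with a stated time of 40 min, tested at 1 uM (on this read-out lower numbers stand for a less stable compound and higher numbers for a more stable compound), compound 2 `CCN(CC)CC1CCN(c2ccc(Nc3nc(NC4CCCCC4)c4nc[nH]c4n3)c(OC)c2)CC1` gives 47%, the lower of the two numbers so far, and compound 1 `COc1cc(N2CCC(CC(=O)N3CCOCC3)CC2)ccc1Nc1nc(NC2CCCCC2)c2nc[nH]c2n1` gives 61%. Compound 3 `COc1cc(N2CCC(CC(=O)N3CCC(N(C)C)C3)CC2)ccc1Nc1nc(NC2CCCCC2)c2nc[nH]c2n1` differs from compound 2 in one place: (3-(dimethylamino)pyrrolidin-1-yl)carbonyl in place of diethylamino on a saturated chain carbon bound to a saturated ring carbon. Put simply, (3-(dimethylamino)pyrrolidin-1-yl)carbonyl stands in place of diethylamino on a saturated chain carbon bound to a saturated ring carbon. Among the measured compounds shown here, one measured step bears on this change, at the same place: a number 14 percentage points lower from compound 1 to compound 2 (beyond the scatter), a modest step beyond the scatter, with diethylamino in place of (morpholin-4-yl)carbonyl. Compound 3 shares a carbonyl with compound 1 but has a different ring and also carries dimethylamino, so only part of that step is expected to return, as a small rise in this assay. The expected change is a number 7 percentage points higher from compound 2 to compound 3 (within the scatter). The estimate for compound 3 is 54%, with an expected range of 40% to 68%.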

Compound 3, percent of the compound remaining: 48%
The estimate for compound 3 lay 6 percentage points above the measured number; the measured number falls inside the stated range.
By their numbers in this assay, from the lowest: compounds 2 and 3 (each within the scatter of the next); then compound 1.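

In this assay, putting (3-(dimethylamino)pyrrolidin-1-yl)carbonyl in place of diethylamino gives a number 1 percentage points higher from compound 2 to compound 3 (within the scatter) and so does not recover the number seen with the morpholine amide. Keeping the carbonyl and changing only the ring on it, with 3-(dimethylamino)pyrrolidin-1-yl in place of morpholin-4-yl, gives a number 13 percentage points lower from compound 1 to compound 3 (beyond the scatter) in the same assay. Among these three compounds, having a carbonyl at this place is therefore not enough to match compound 1, and only the compound carrying morpholin-4-yl stands apart.

As far as these compounds go, it remains open whether a carbonyl bearing a piperidin-1-yl ring, which has no second amine, would read like compound 1 or like compound 3. No measured evidence accounts for these differences.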